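Swapping a Benzofuran for a Furan on a Nucleoside Core

The source may report more compounds than this note shows. Statements on the series, on what has been measured and on what is new or still open speak of the compounds shown alone.

Compound 1, `COc1nc(N)nc2c1c(-c1cc3ccccc3o1)cn2[C@@H]1O[C@H](CO)[C@@H](O)[C@H]1O`, is the starting point. In a functional assay on K562 cells (Homo sapiens), read by MTT assay, with a stated time of 72 h (a higher number here means a weaker inhibitor, a lower number a stronger inhibitor), compound 1 gives 14600 nM, the lowest of the two plain numbers available, with the nearest neighbour being compound 2, `COc1ncnc2c1c(-c1cc3ccccc3o1)cn2[C@@H]1O[C@H](CO)[C@@H](O)[C@H]1O`, at 20900 nM. Within the data shown here, the only measured step, a 1.4-fold higher number from compound 1 to compound 2 (0.16 log units; within the scatter), changes a different part of the molecule and is within the scatter. Compound 3, `C#Cc1cn([C@@H]2O[C@H](CO)[C@@H](O)[C@H]2O)c2ncnc(NC)c12`, gives only > 20000 nM in this assay, which is a limit of the measurement rather than a number; the limit of > 20000 nM in this assay, at which 1 of the 3 values shown sits, marks where such limits sit.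

The compound not yet measured is compound 4, `COc1nc(N)nc2c1c(-c1ccco1)cn2[C@@H]1O[C@H](CO)[C@@H](O)[C@H]1O`. Its difference from compound 1 is furan-2-yl in place of 1-benzofuran-2-yl on an aromatic carbon. Among the measured compounds shown here, no measured step in this set changes this group, so nothing directly shows how large a shift to expect. For the measured compounds named here, with compound 1 at 14600 nM and the one measured step within the scatter, the expectation is a step of a 1.4-fold higher number from compound 1 to compound 4 (0.14 log units; within the scatter), with no clear direction. Compound 4 is therefore estimated at about 20000 nM in this assay, within a range of 6000 nM to 60000 nM, and with a real chance that only a limit is reported.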

Compound 4, half-maximal inhibitory concentration: > 20000 nM
Compound 4: only a limit was reported; the forecaster's own chance of this, stated with the estimate: 45%; the middle value lies on the limit itself.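

Replacing 1-benzofuran-2-yl with furan-2-yl on this aromatic carbon removes the six-membered aromatic ring of carbon only and gives an at least 1.3-fold higher number from compound 1 to compound 4 (0.13 log units; that floor lies within the scatter) in this assay. On these data alone, the value of compound 4 is a limit, so the true size of this step stays unknown: it may be small, or much larger than its floor. The earlier compounds held no step at this position, and this first one gives no sign that the smaller furan-2-yl group lowers the number, while compound 4 joins the compounds reported only as a limit: the limit of > 20000 nM in this assay, at which 2 of the 4 values shown sit.

The compounds shown leave open whether a different group on this carbon, such as a phenyl ring or a simple amine, would move the number beyond the scatter in either direction. They also leave open whether, with furan-2-yl in place, hydrogen instead of amino on the core would matter as little as it does with 1-benzofuran-2-yl, where the step is a 1.4-fold higher number from compound 1 to compound 2 (0.16 log units; within the scatter).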